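Urea to amide: a swap at the carbonyl carbon

A few compounds are considered here, and "the series" means these few. Any claim that something is new, unique, unknown or untested is made for them only; others in the source may bear on it.

Measured compounds: compound 1 `COc1cc(Cl)cc(-c2nn(-c3cccc(NC(=O)Nc4ccc(Cl)c(C(F)(F)F)c4)c3)cc2-c2ccncc2)c1`, 3.39%; compound 2 `COc1cc(Cl)cc(-c2nn(-c3cccc(NC(=O)c4cc(C(F)(F)F)cc(C(F)(F)F)c4)c3)cc2-c2ccncc2)c1`, 35.2%.

In a functional assay on HCT-116 cells (Homo sapiens) for inhibition, read by sulforhodamine B assay, with a stated time of 48 h, tested at 10 uM (a lower number here means a stronger effect, a higher number a weaker effect of the compound at the concentration tested), compound 1 gives the lowest of the two numbers, and compound 2 lies higher by a margin beyond the scatter. Compound 3 `COc1cc(Cl)cc(-c2nn(-c3cccc(NC(=O)c4cccc(C(F)(F)F)c4)c3)cc2-c2ccncc2)c1` is not yet measured. It differs from compound 1 in one place: 3-(trifluoromethyl)phenyl in place of (4-chloro-3-(trifluoromethyl)phenyl)amino on a carbonyl carbon. Compound 2 also carries an amide in place of the urea and gives 35.2%, so a step upward is expected here, estimated as a number 41.6 percentage points higher from compound 1 to compound 3 (beyond the scatter). Compound 3 is therefore expected at 45%, within 15% to 80%.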

Compound 3, a percentage reported as activity, at one concentration (the size of the read-out at that concentration, not a potency): 34.1%
Compound 3: middle estimate off by 10.9 percentage points, on the high side; the range from low to high includes it.
By their numbers in this assay, from the lowest: compound 1; then compounds 3 and 2 (each within the scatter of the next).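

In this assay, replacing (4-chloro-3-(trifluoromethyl)phenyl)amino on the carbonyl carbon with 3-(trifluoromethyl)phenyl gives a number 30.7 percentage points higher from compound 1 to compound 3 (beyond the scatter), so this position responds strongly to the change. Replacing one trifluoromethyl with hydrogen on the amide side gives a number 1.1 percentage points lower from compound 2 to compound 3 (within the scatter), so that group makes no clear difference here. No measurement on hand explains either result.

From the compounds shown here alone, the first step changes the amino nitrogen and the chlorine together, so their separate contributions remain unknown. Going by these compounds, how a nitrile in place of the remaining trifluoromethyl would behave also stays open.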